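A few compounds are considered here, and "the series" means these few. Any claim that something is new, unique, unknown or untested is made for them only; others in the source may bear on it.

Working notes on the series.

Compound 1 `CN(C(=O)NC(=O)c1cccc([N+](=O)[O-])c1)c1nc(C(F)(F)F)c(C(=O)N/N=C/c2ccccc2C(F)(F)F)s1` carries the shared core with a 3-nitrophenyl on the carbonyl carbon of the acylurea. In a functional assay on BCG823 cells (Homo sapiens) for inhibition, read by MTT assay, with a stated time of 72 h (a lower number here means a stronger inhibitor, a higher number a weaker inhibitor), compound 1 gives 3.97 ug/mL, which is the lower of the two numbers measured in this series; the nearest value, that of compound 2 `CN(C(=O)NC(=O)c1ccc(Cl)c(Cl)c1)c1nc(C(F)(F)F)c(C(=O)N/N=C/c2cccc([N+](=O)[O-])c2)s1` at 4.87 ug/mL, lies within the scatter of it, so no order between the two can be claimed. Compound 3 `CNc1nc(C)c(C(=O)N/N=C/c2cc(C(F)(F)F)cc(C(F)(F)F)c2)s1`, with a different substitution pattern on the core, gives only a limit in this assay, > 100 ug/mL; one of the three values sits at the limit of > 100 ug/mL in this assay, at which 1 of the 3 values shown sits.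

Compound 4 `CN(C(=O)NC(=O)c1c(Cl)cccc1Cl)c1nc(C(F)(F)F)c(C(=O)N/N=C/c2ccccc2C(F)(F)F)s1` is not yet measured. Against compound 1 the difference is 2,6-dichlorophenyl in place of 3-nitrophenyl on a carbonyl carbon. Compound 2 shows that a dichlorophenyl on that carbonyl carbon, together with another hydrazone aryl, still gives a number close to that of compound 1. A step in this assay of no more than the scatter, or a slightly weaker inhibition, is expected: a 1.4-fold higher number from compound 1 to compound 4 (0.14 log units; within the scatter). For compound 4 the estimate is 5.5 ug/mL, with a range from 2 ug/mL to 16 ug/mL.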

Compound 4, half-maximal inhibitory concentration: 4.12 ug/mL
Compound 4: the middle estimate sits 1.3-fold (0.13 log units) above what was measured; the range from low to high includes it.
By their numbers in this assay, from the lowest: compounds 1, 4 and 2 (each within the scatter of the next). At a limit, above all of these: compound 3.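

In this assay, within the data shown here, 2,6-dichlorophenyl in place of 3-nitrophenyl on a carbonyl carbon whose other neighbour is an amide-type nitrogen gives a 1.0-fold higher number from compound 1 to compound 4 (0.02 log units; within the scatter), and this is the first comparison that changes one place alone. Compound 2 differs from compound 1 in two places and could not separate the acylurea aryl from the hydrazone aryl, whereas this pair shows that both aryl groups are accepted here with the rest of the molecule held the same. No measured property among the data bears on this result.

On these data alone, whether an aromatic ring is needed on this carbonyl carbon stays open, since a cyclohexyl group, a longer alkyl chain or a carboxylic acid on the ring could behave differently. The value of compound 3, > 100 ug/mL, is a limit, and that compound differs from the others in more than one place, so what separates it cannot be assigned.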